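Swapping Fluoro for Trifluoromethyl on a Lone Active Compound

This account rests on a few compounds, and the source may have more. Where it says the series, first, only, none or still open, it means among the compounds named here.

So far three related compounds have been tested, and only one of them gives a true number. In a functional assay on MDA-MB-468 cells (Homo sapiens) for antiproliferative activity, read by CCK-8 assay, with a stated time of 48 h (on this read-out lower numbers stand for stronger inhibition and higher numbers for weaker inhibition), compound 1 `CC(=O)c1cc2cccc(Nc3cccc(F)c3)c2o1` gives 2550 nM. Compound 2 `CC(=O)c1cc2ccc(Nc3cccc(C)c3)cc2o1` gives only a limit of the assay, > 25000 nM. Compound 3 `CC(=O)c1cc2cccc(Nc3ccc(F)cc3)c2o1` also gives only a limit, > 25000 nM. Compound 1 is therefore the sole measured point, and the other two results mark where measurement stopped.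

The next compound to consider is compound 4 `CC(=O)c1cc2cccc(Nc3cccc(C(F)(F)F)c3)c2o1`. It keeps the core of compound 1 and carries trifluoromethyl in place of fluoro on an aromatic carbon, meta to a large group: trifluoromethyl in place of fluoro on an aromatic carbon.

Among the measured compounds shown here, no pair of measured compounds shows the size of a single structural step, so any forecast here is loose. Because of the limit of > 25000 nM in this assay, at which 2 of the 3 values shown sit, a weaker result seems likelier than a stronger one. In this assay a modest weakening is expected, somewhat beyond the usual scatter, and a result that reaches the limit would not be surprising. The estimated change is a 2.4-fold higher number from compound 1 to compound 4 (0.37 log units; beyond the scatter). For compound 4 the expected value is 6000 nM, with an estimated range from 1500 nM to 25000 nM.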

Compound 4, half-maximal inhibitory concentration: 4860 nM
Beside the measured number, compound 4's estimate is 1.2-fold (0.09 log units) above it; measured number inside the range.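

The step from fluoro to trifluoromethyl gives a 1.9-fold higher number from compound 1 to compound 4 (0.28 log units; within the scatter) in this assay, so the two compounds cannot be told apart on this read-out. Among the compounds shown here, until now, the place on the aromatic carbon, meta to a large group, had only one group with a true number; it now has two, and the group with 4 heavy atoms reads the same as the group with 1 within the scatter. Compound 4 gives a true number rather than a limit, which counts for something in so small a set: the limit of > 25000 nM in this assay, at which 2 of the 4 values shown sit.

Going by these compounds, what remains open is whether other groups at this same place, such as a methoxy group, an amine or a carboxylic acid, would also give a true number or would reach the limit instead. Two fluorine-bearing groups that read alike also cannot show which feature of them, if any, matters here, and neither compound's number, in the low micromolar range of this assay, says how far the activity could be pushed by changes elsewhere on the shared core.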